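Methoxy to hydroxy on the aryl ring: cytotoxicity check

A few compounds are considered here, and "the series" means these few. Any claim that something is new, unique, unknown or untested is made for them only; others in the source may bear on it.

Three compounds share a core carrying a nitrile-bearing side chain and have been run in a functional assay on Malme-3M cells (Homo sapiens) for cytotoxicity, read by sulforhodamine B assay, with a stated time of 48 h, tested at 10 uM; on this read-out higher numbers stand for a weaker effect at the one concentration tested and lower numbers for a stronger effect. Compound 1 `COc1cc(C)cc(-c2c(-c3ccnc(-c4ccc(N(C)C)cc4)c3)cnn2CC#N)c1` gives 13% in this assay. Compound 2 `COc1cc(C)cc(-c2nn(CC#N)cc2-c2ccnc(-c3ccc(N(C)C)cc3)c2)c1` gives 5% in this assay. Compound 3 `COc1cc(C)cc(-c2nn(CC#N)cc2-c2ccc(-c3cccc(C(C)=O)c3)nc2)c1` gives -1% in this assay. The three numbers fall within the scatter of one another, so compound 2 differs from compound 1 and from compound 3 by less than repeat measurements usually differ, and none of the three can be called stronger or weaker than the others; all sit at the weak end of the read-out.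

The next compound, compound 4 `Cc1cc(O)cc(-c2nn(CC#N)cc2-c2ccnc(-c3ccc(N(C)C)cc3)c2)c1`, is not yet measured. It differs from compound 2 in one place: hydrogen in place of methyl on an oxygen on an aromatic ring. Within the data shown here, no step between measured compounds concerns this change, so nothing shows how it moves the read-out. Given the uniformly weak numbers, no step beyond the scatter in either direction is expected from compound 2 to compound 4 in this assay, and the estimated step is a number 1 percentage points higher from compound 2 to compound 4 (within the scatter). Compound 4 is thus expected to give about 6% in this assay, within a range from -8% to 22%.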

Compound 4, a percentage reported as activity, at one concentration (the size of the read-out at that concentration, not a potency): -19%
Compound 4: middle estimate off by 25 percentage points, on the high side; the whole stated range lies above it.
By their numbers in this assay, from the lowest: compound 4; then compounds 3, 2 and 1 (each within the scatter of the next, the first and the last beyond it).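

In this assay, replacing methoxy with hydroxy on the 3-methoxy-5-methylphenyl ring gives a step of a number 24 percentage points lower from compound 2 to compound 4 (beyond the scatter), toward a stronger effect at the one concentration tested. Among these compounds, this is the only step that isolates a single change, and it shows that the read-out responds to what sits on this aromatic oxygen, which the three earlier compounds could not show. The size of the read-out is affected here, not a potency, and nothing available bears on why the change acts this way.

As far as these compounds go, whether the same change moves the read-out likewise on the frameworks of compound 1 or compound 3 remains open. Also open, from the compounds shown here alone, is whether the free hydroxy is specifically required, or whether an amine or an ethoxy group at this place would give a similar read-out.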